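The source may hold more compounds than are shown below. What is called first, only, known or untested is meant among the compounds shown, and "the series" means these compounds.

Measured compounds:
- Compound 1 `CC(=O)NCc1cccc(Cn2nc(NS(=O)(=O)c3ccc(Cl)s3)c3c(F)cccc32)c1` gives 5010 nM in an assay on isolated protein (blood) for antagonist activity at C-C chemokine receptor type 4 (Homo sapiens), read by flow cytometry, with a stated time of 30 min; on this read-out higher numbers stand for weaker binding and lower numbers for tighter binding.
- Compound 2 `CC(=O)NCc1cccc(Cn2nc(NS(=O)(=O)c3ccc(Cl)s3)c3c(C(C)O)cccc32)c1` gives 501 nM in this assay.

Compound 2 stands at the lowest of the two numbers, and its nearest neighbour, compound 1, sits a step away described by a 10-fold lower number from compound 1 to compound 2 (1.00 log units; beyond the scatter). Compound 3 `CC(=O)NCc1cccc(Cn2nc(NS(=O)(=O)c3ccc(Cl)s3)c3c(C(F)F)cccc32)c1` is not yet measured. It differs from compound 2 by difluoromethyl in place of 1-hydroxyethyl on an aromatic carbon. Going by the values given here, the one measured step that bears on this is a 10-fold lower number from compound 1 to compound 2 (1.00 log units; beyond the scatter), which swapped fluoro for 1-hydroxyethyl at the same place and moved the number markedly. From the compounds shown here alone, compound 3 removes the 1-hydroxyethyl and puts a fluorine-bearing group back, so the number is expected to move back toward that of compound 1, though whether a difluoromethyl behaves like a single fluoro is unknown. The expected step is a 3.2-fold higher number from compound 2 to compound 3 (0.50 log units; beyond the scatter), a higher number. Compound 3 is therefore estimated at 1600 nM, within a range from 400 nM to 6300 nM.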

Compound 3, dissociation constant in the C-C chemokine receptor type 4 assay: 7940 nM
Estimate against measurement, compound 3: 5.0-fold (0.70 log units) below; measured number above the stated range.
By their numbers in the C-C chemokine receptor type 4 assay, from the lowest: compound 2; then compounds 1 and 3 (each within the scatter of the next).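

At this place on the aromatic ring, in the C-C chemokine receptor type 4 assay compound 3 gives 7940 nM, and the read-out shows a 16-fold higher number from compound 2 to compound 3 (1.20 log units; beyond the scatter), so the tighter binding of compound 2 is lost when difluoromethyl replaces 1-hydroxyethyl. Difluoromethyl and fluoro cannot be told apart on this read-out, with a 1.6-fold higher number from compound 1 to compound 3 (0.20 log units; within the scatter), so among these three compounds only the one carrying 1-hydroxyethyl stands out. In a physicochemical assay for solubility, read by chemiluminescence, measured as kinetic solubility (a lower number here means a less soluble compound, a higher number a more soluble compound), compound 2 gives >= 208 ug/mL, which is a limit and not a number. In the physicochemical assay compound 3 gives >= 188 ug/mL, which is also a limit and not a number. The step between the two cannot be read.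

The compounds shown leave open whether the tighter binding belongs to the hydroxyl group or to the carbon chain of 1-hydroxyethyl, a question that an ethyl group or a hydroxymethyl group at this place could separate. Nothing measured here gives a cause for the change in binding.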